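The compounds below may be only part of what the source reports. "The series", "measured", "known", "first", "only" and "open" are said of these compounds alone.

Compound 1 `Cn1c(-c2ccc(Br)cc2)cnc1NC(=O)c1ccc(F)cc1` and compound 2 `Cc1ccc(-c2cnc(NC(=O)c3ccc(F)cc3)n2C)cc1` share one core and differ in a single place. In a toxicity assay on THP-1 cells (Homo sapiens) for inhibition (a higher number here means that more compound is tolerated, a lower number that less compound is tolerated), compound 1 gives 46000 nM, while compound 2 gives 60000 nM. The change between them, (bromo in place of methyl on an aromatic carbon), produced a 1.3-fold lower number from compound 2 to compound 1 (0.12 log units; within the scatter). Compound 3 `Cc1ccc(C(=O)Nc2ncc(-c3ccccc3)n2C)cc1` carries another core, and how it differs from compound 2 is not broken down here. In this assay compound 3 reaches only a limit, > 50000 nM, and the limit of > 50000 nM in this assay, at which 1 of the 3 values shown sits, marks that same point. Compound 4 `Cn1c(-c2ccccc2)cnc1NC(=O)c1ccc(Br)cc1` is compound 3 with the same change made at the same place, (bromo in place of methyl on an aromatic carbon), on an aromatic carbon of a six-membered aromatic ring of carbon only, para to a large group. Since a 1.3-fold lower number from compound 2 to compound 1 (0.12 log units; within the scatter) stayed within the scatter, the expectation is that this second step is of similar small size, a step that the limit leaves unreadable from compound 3 to compound 4. Compound 4 is therefore estimated at 55000 nM, somewhere between 25000 nM and 120000 nM, with a real chance that this assay again reports only a limit rather than a number.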

Compound 4, half-maximal cytotoxic concentration: > 100000 nM
Compound 4 ended at the assay's limit (the forecaster's own chance of this, stated with the estimate: 55%); middle value at least 1.8-fold (0.25 log units) from the limit.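

In this assay compound 3 gives > 50000 nM, which is a limit and not a number. Compound 4 gives > 100000 nM, also a limit. No step can be read between these two compounds. The compounds shown leave open whether going from 4-methylphenyl to 4-bromophenyl changes the tolerated concentration in this pair at all.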